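The source may hold more compounds than are shown below. What is called first, only, known or untested is meant among the compounds shown, and "the series" means these compounds.

In a functional assay on SK-MEL-28 cells (Homo sapiens) for inhibition, read by sulforhodamine B assay, with a stated time of 48 h (on this read-out higher numbers stand for weaker inhibition of growth and lower numbers for stronger inhibition of growth), compound 1 `COc1ccc(-c2[nH]c3ccccc3c2/C=C(\C#N)S(=O)(=O)c2ccccc2)cc1` gives 1800 nM, the lowest of the three numbers at hand. Compound 2 `COc1ccc2[nH]c(-c3ccccc3)c(C=C(C#N)C#N)c2c1` gives 4400 nM and compound 3 `CCOC(=O)C(=Cc1c(-c2ccccc2)[nH]c2ccccc12)C(=O)OCC` gives 7700 nM; both gaps from compound 1 lie beyond the usual scatter, so among these three compound 1 is the strongest inhibitor of growth. Compound 4 `COc1ccc(-c2[nH]c3ccc(OC)cc3c2/C=C(\C#N)S(=O)(=O)c2ccccc2)cc1` has not been measured. It differs from compound 1 by methoxy in place of hydrogen on an aromatic carbon. Going by the values given here, no measured pair shows this change on its own, so no step can be drawn from the data; compound 2 carries a methoxy too, but its other differences from compound 1 hide what the methoxy alone does. The step of a 1.2-fold lower number from compound 1 to compound 4 (0.08 log units; within the scatter) is expected to stay within the scatter. Compound 4 is estimated in this assay at 1500 nM, within 500 nM to 5000 nM.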

Compound 4, concentration for 50% growth inhibition: 787 nM
Compound 4: middle estimate off by 1.9-fold (0.28 log units), on the high side; the range from low to high includes it.
By their numbers in this assay, from the lowest: compound 4; then compound 1; then compounds 2 and 3 (each within the scatter of the next).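

In this assay, methoxy in place of hydrogen on this aromatic carbon, meta to a fused ring and para to a fused ring, gives a 2.3-fold lower number from compound 1 to compound 4 (0.36 log units; beyond the scatter), a modest step beyond the scatter. Going by these compounds alone, this isolates the effect of the change for the first time, and this position accepts the methoxy with stronger inhibition of growth rather than a loss. No evidence at hand accounts for the step. Going by these compounds, whether a hydroxyl, a chlorine or a longer alkoxy chain would act the same way here remains open. So does the effect of methoxy on the other carbons of that ring.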